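A phenyl exchange from compound 3 to compound 4

The source may hold more compounds than are shown below. What is called first, only, known or untested is meant among the compounds shown, and "the series" means these compounds.

- compound 1 `O=C(N/N=C/c1ccc(F)cc1Cl)Nc1cc2c(Nc3ccc(F)c(Cl)c3)ncnc2cc1O[C@H]1CCOC1` with 26100 nM
- compound 2 `O=C(N/N=C/c1ccc(O)c(Br)c1)Nc1cc2c(Nc3ccc(F)c(Cl)c3)ncnc2cc1O[C@H]1CCOC1` with 660 nM
- compound 3 `COc1cc2ncnc(Nc3ccc(F)c(Cl)c3)c2cc1NC(=O)N/N=C/c1ccc(F)cc1Cl` with 29200 nM

In a functional assay on HepG2 cells (Homo sapiens) for cytotoxicity, read by MTT assay, with a stated time of 72 h (a lower number here means a stronger inhibitor, a higher number a weaker inhibitor), compound 3 stands at 29200 nM and thus level with compound 1 within the scatter, while compound 2 lies far lower at 660 nM on the same scale. Compound 4 `COc1cc2ncnc(Nc3ccc(F)c(Cl)c3)c2cc1NC(=O)N/N=C/c1ccc(O)c(Br)c1` keeps the methyl on the oxygen of compound 3 and differs in one place (3-bromo-4-hydroxyphenyl in place of 2-chloro-4-fluorophenyl on a carbon with a double bond to nitrogen). The same exchange has been measured once, as a 40-fold lower number from compound 1 to compound 2 (1.60 log units; beyond the scatter) and thus a large step. Methyl in place of oxolan-3-yl gave no change beyond the scatter (a 1.1-fold higher number from compound 1 to compound 3 (0.05 log units; within the scatter)), so the large step may carry over, though a single pair cannot prove it. In this assay a lower number of similar size is therefore expected (a 40-fold lower number from compound 3 to compound 4 (1.60 log units; beyond the scatter)). Compound 4 is estimated at 730 nM with an expected range from 250 nM to 2500 nM in this measurement.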

Compound 4, half-maximal inhibitory concentration: 23800 nM
For compound 4 the middle estimate is 33-fold (1.51 log units) below the measured one; measured number outside the range, above it.
By their numbers in this assay, from the lowest: compound 2; then compounds 4, 1 and 3 (each within the scatter of the next).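

The exchange to 3-bromo-4-hydroxyphenyl on a carbon with a double bond to nitrogen gives only a 1.2-fold lower number from compound 3 to compound 4 (0.09 log units; within the scatter) in this assay, so its effect depends on the core that carries it: the same change on two cores in this assay, a 40-fold lower number (1.60 log units; beyond the scatter) from compound 1 to compound 2 and a 1.2-fold lower number (0.09 log units; within the scatter) from compound 3 to compound 4, 32-fold (1.51 log units) apart, beyond the scatter of two such steps. Methyl in place of oxolan-3-yl on an oxygen on an aromatic ring, which made no difference beyond the scatter with 2-chloro-4-fluorophenyl, now gives a 36-fold higher number from compound 2 to compound 4 (1.56 log units; beyond the scatter), so the two places do not act independently: the same change on two cores in this assay, a 1.1-fold higher number (0.05 log units; within the scatter) from compound 1 to compound 3 and a 36-fold higher number (1.56 log units; beyond the scatter) from compound 2 to compound 4, 32-fold (1.51 log units) apart, beyond the scatter of two such steps. Only the combination of oxolan-3-yl and 3-bromo-4-hydroxyphenyl in compound 2 stands apart from the other three, at 660 nM.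

The compounds shown leave open whether the hydroxy group or the bromine carries this low number. They also leave open whether an amine or a longer chain on that oxygen would keep it.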